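The source may hold more compounds than are shown below. What is called first, only, known or untested is meant among the compounds shown, and "the series" means these compounds.

Working notes on the series. Of the compounds shown here, two have numbers so far. Compound 1, `CCCCCCCCCCCCCCCC(=O)OCC(COP(=O)(O)OCCN)OC`, gives in a functional assay on PC-3 cells (Homo sapiens) for cytotoxicity, read by resazurin assay, with a stated time of 48 h, tested at 50 uM (a lower number here means a stronger effect, a higher number a weaker effect of the compound at the concentration tested), a read-out of 24.9%. Compound 2, `CCCCCCCCCCCCCC(=O)OCC(COP(=O)(S)OCCN)OC`, gives in this assay a read-out of 43.8%. On these two numbers compound 2 stands highest, and its gap to compound 1 lies beyond the scatter; no structural difference between compound 1 and compound 2 is counted here, so only the two values are noted.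

Compound 3, `CCCCCCCCCCCCCCCC(=O)OCC(COP(=O)(S)OCCN)OC`, is not yet measured in this assay. The change from compound 2 to compound 3 is ethyl in place of hydrogen on a saturated chain carbon, ten or more bonds along the chain from a carbonyl carbon. Among the measured compounds shown here, no step between measured compounds covers this kind of change, so the series gives no direct guide to its size. Compound 3 is expected to stay close to compound 2, with the step of a number 5.8 percentage points lower from compound 2 to compound 3 (within the scatter) expected to be small, if anything toward a slightly lower number, and not beyond the scatter. Compound 3 is thus estimated at 38%, within a range from 20% to 56%.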

Compound 3, a percentage reported as activity, at one concentration (the size of the read-out at that concentration, not a potency): 70%
The estimate for compound 3 lay 32 percentage points below the measured number; the measured number lies above the stated range.
By their numbers in this assay, from the lowest: compound 1; then compound 2; then compound 3.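

In this assay, ethyl in place of hydrogen on a saturated chain carbon, ten or more bonds along the chain from a carbonyl carbon, gives a number 26.2 percentage points higher from compound 2 to compound 3 (beyond the scatter), so a change this far out along the chain is not silent and goes with a weaker effect at the concentration tested. Sulfanyl in place of hydroxy on a phosphorus, a change that the earlier compounds did not isolate, gives a number 45.1 percentage points higher from compound 1 to compound 3 (beyond the scatter), which shows that the phosphorus position also matters and that this change likewise moves the read-out toward a weaker effect. Nothing measured here explains either step.

Among the compounds shown here, a single chain step leaves open whether the number keeps rising with a longer chain, or whether a shorter chain would reverse the direction, and the same chain step has no counterpart among the compounds carrying hydroxy on the phosphorus, so the two changes cannot yet be judged in combination. Also open, on these data alone, is how the series would respond to a trimethylammonium group in place of the terminal amine, or an amide in place of the ester.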